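Swapping the urea partner: from compound 2 to compound 3

A few compounds are considered here, and "the series" means these few. Any claim that something is new, unique, unknown or untested is made for them only; others in the source may bear on it.

Compound 1 `COc1cccc(S(=O)(=O)Nc2cccc(-c3nc(-c4ccc(NC(=O)c5cccnc5)cc4Cl)no3)c2)c1`: > 10000 nM (a limit of the assay, not a number)
Compound 2 `O=C(Nc1cccc(-c2nc(-c3ccc(NC(=O)c4cccnc4)cc3Cl)no2)c1)Nc1cccc(C(F)(F)F)c1`: 1900 nM

In a functional assay on MDA-MB-231 cells (Homo sapiens) for antiproliferative activity, read by MTT assay, with a stated time of 72 h (on this read-out higher numbers stand for weaker inhibition and lower numbers for stronger inhibition), compound 2 gives 1900 nM, the only number shown. Compound 1 sits at the assay limit (the limit of > 10000 nM in this assay, at which 1 of the 2 values shown sits). Compound 3 `COc1ccc(NC(=O)Nc2cccc(-c3nc(-c4ccc(NC(=O)c5cccnc5)cc4Cl)no3)c2)cc1` differs from compound 2 by 4-methoxyphenyl in place of 3-(trifluoromethyl)phenyl on an amide-type nitrogen. Among the measured compounds shown here, no measured pair differs in this one place, so the direction rests on expectation alone: the step from compound 2 to compound 3 is expected to be a 2.9-fold higher number from compound 2 to compound 3 (0.46 log units; beyond the scatter), a loss beyond the scatter. Compound 3 is therefore estimated at 5500 nM, with a range from 2000 nM to 15000 nM.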

Compound 3, half-maximal inhibitory concentration: 3000 nM
Estimate against measurement, compound 3: 1.8-fold (0.26 log units) above; measured number inside the range.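

In this assay, 4-methoxyphenyl and 3-(trifluoromethyl)phenyl on the amide-type nitrogen cannot be told apart: a 1.6-fold higher number from compound 2 to compound 3 (0.20 log units; within the scatter). The exchange of (3-methoxyphenyl)sulfonyl for (4-methoxyphenyl)carbamoyl on the nitrogen on an aromatic ring does register: an at least 3.3-fold lower number from compound 1 to compound 3 (0.52 log units; beyond the scatter). Its true size stays unknown, as compound 1 stands at a limit and not at a number: the limit of > 10000 nM in this assay, at which 1 of the 3 values shown sits.

The compounds shown leave open whether the amide-type nitrogen needs an aromatic ring at all, since a cyclohexyl group or a butyl chain there remains untested here. They also leave open how a pyridine ring would compare.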